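The source may report more compounds than this note shows. Statements on the series, on what has been measured and on what is new or still open speak of the compounds shown alone.

Compound 1 `CC1=C(c2cccc(O)c2)[C@H](c2ccc(OC[C@H](C)N3CC[C@@H](C)C3)cc2)Oc2ccc(O)cc21`: 0.1 nM
Compound 2 `CC1=C(c2cccc(O)c2)C(c2ccc(OC[C@H](C)N3CC[C@@H](C)C3)cc2)Oc2ccc(O)cc21`: 0.2 nM
Compound 3 `CC1=C(c2cccc(O)c2)C(c2ccc(OC[C@H](C)N3CCCC3)cc2)Oc2ccc(O)cc21`: 0.2 nM

Of the compounds shown here, three have been measured in a functional assay on MCF7 cells (Homo sapiens) for antiproliferative activity, read by CellTiter-Glo, with a stated time of 5 days; on this read-out higher numbers stand for weaker inhibition and lower numbers for stronger inhibition. Compound 2 gives 0.2 nM, which agrees at the digits shown with compound 3; from compound 1 the step is a 2.0-fold higher number from compound 1 to compound 2 (0.30 log units; within the scatter), and the only change there is a stereocentre drawn in one and not the other (the fact that one of compounds 1 and 2 is drawn with a defined configuration and the other without, at the place where they differ). The step of no change at the digits printed from compound 2 to compound 3 (within the scatter) likewise stays within the scatter.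

Compound 4 `CC1=C(c2ccc(F)cc2)C(c2ccc(OC[C@H](C)N3CC[C@@H](C)C3)cc2)Oc2ccc(O)cc21` is not yet measured. It differs from compound 2 by 4-fluorophenyl in place of 3-hydroxyphenyl on a double-bonded ring carbon. Neither measured step touches this part of the shared core, so neither gives a direct guide. Compound 4 is expected to show a step of a 5.0-fold higher number from compound 2 to compound 4 (0.70 log units; beyond the scatter), towards a higher number, with wide uncertainty. Compound 4 is estimated at 1 nM, between 0.2 nM and 6 nM.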

Compound 4, half-maximal inhibitory concentration: 0.4 nM
Compound 4: the middle estimate sits 2.5-fold (0.40 log units) above what was measured; the measured number falls inside the stated range.
By their numbers in this assay, from the lowest: compounds 1, 2, 3 and 4 (each within the scatter of the next, the first and the last beyond it).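

For the compounds shown here, at the double-bonded ring carbon, which the earlier steps left untouched, 4-fluorophenyl in place of 3-hydroxyphenyl gives a 2.0-fold higher number from compound 2 to compound 4 (0.30 log units; within the scatter) in this assay. The aromatic ring at this position can therefore go from one hydrogen-bond donor and one acceptor to none without a step beyond the scatter. Nothing in the available evidence accounts for this step.

The compounds shown do not separate removing the hydroxyl from adding the fluorine, since the two change together. Going by these compounds, how a nitrile or an amine on this phenyl ring would read also stays open.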